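Pyridin-3-yl for 3-methoxyphenyl: a half-life estimate

The compounds below may be only part of what the source reports. "The series", "measured", "known", "first", "only" and "open" are said of these compounds alone.

Compound 1 `Cn1ncc2c(=O)n(-c3ccccc3)c(SCc3cccc(F)c3)cc21` gives 0.15 h
Compound 2 `C[C@@H](Sc1nc2c(cnn2C)c(=O)n1-c1ccccc1)c1ccccc1` gives 0.133 h
Compound 3 `COc1cccc(C(C)Sc2nc3c(cnn3C)c(=O)n2-c2ccccc2)c1` gives 0.1 h

Half-life in a liver preparation shows how long a compound survives there, and it is a common early check on a new molecule. In an ADME assay on microsomes from liver (Mus musculus, strain CD-1) for metabolic stability, read by LC-MS, with a stated time of 60 min, tested at 20 uM (on this read-out higher numbers stand for a longer-lived compound and lower numbers for a shorter-lived compound), the three measured compounds sit close together. Compound 3 gives 0.1 h and stands within the usual scatter of both compound 1 and compound 2, so the numbers do not separate these compounds.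

Compound 4 `CC(Sc1nc2c(cnn2C)c(=O)n1-c1ccccc1)c1cccnc1` has not been measured yet. It carries pyridin-3-yl in place of 3-methoxyphenyl on a saturated chain carbon bound to a saturated chain carbon and a sulfur.

Within the data shown here, no two measured compounds differ in just one place, so the data do not show how far a single change can move this assay in this family. The expectation therefore stays modest: a small upward move that does not clearly leave the scatter, starting from compound 3 at 0.1 h and resting on the tight grouping of the three values. The estimated step is a 1.8-fold higher number from compound 3 to compound 4 (0.26 log units; within the scatter) and nothing larger can be argued from so few numbers. For compound 4 the estimate is 0.18 h (expected range 0.08 h to 0.4 h).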

Compound 4, half-life: 0.117 h
For compound 4 the middle estimate is 1.5-fold (0.19 log units) above the measured one, within the range that was stated.
By their numbers in this assay, from the lowest: compounds 3, 4, 2 and 1 (each within the scatter of the next).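

Among these compounds, these results give the first comparisons in which only one place changes, and they concern the group on a saturated chain carbon bound to a saturated chain carbon and a sulfur. In this assay, pyridin-3-yl in place of 3-methoxyphenyl gives a 1.2-fold higher number from compound 3 to compound 4 (0.07 log units; within the scatter), and 1-(pyridin-3-yl)ethyl in place of 1-phenylethyl on the sulfur gives a 1.1-fold lower number from compound 2 to compound 4 (0.06 log units; within the scatter), so neither change can be told apart from the scatter of repeated measurements. Within these compounds, then, the half-life does not separate the phenyl, 3-methoxyphenyl and pyridin-3-yl rings, and nothing shown here gives a reason for this closeness.

As far as these compounds go, whether this place can move the half-life at all remains open, since the three rings compared are all six-membered aromatic rings and a quite different group, such as an amine or a carboxylic acid on the chain, could behave differently. It is also unknown whether a longer chain in place of the methyl on that same carbon, or a change elsewhere on the shared core, would produce a step beyond the scatter.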